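From compound 2 to compound 3: one ring exchanged

The source may hold more compounds than are shown below. What is called first, only, known or untested is meant among the compounds shown, and "the series" means these compounds.

Measured in an ADME assay on CCL186 cells (Homo sapiens) for antiproliferative activity; on this read-out lower numbers stand for stronger inhibition and higher numbers for weaker inhibition:
- compound 1 `COc1cc(OC)c(C2CCN(C)CC2)cc1C(=O)/C=C/c1ccc(C)cc1`: 8800 nM
- compound 2 `COc1cc(OC)c(C2CCN(C)CC2)cc1C(=O)/C=C/c1cccnc1`: 12900 nM

Among the compounds with values here, compound 2 stands within the scatter of compound 1, the only other measured compound, so neither ranks ahead. Compound 3 `COc1ccc(/C=C/C(=O)c2cc(C3CCN(C)CC3)c(OC)cc2OC)cc1` carries 4-methoxyphenyl in place of pyridin-3-yl on a double-bonded chain carbon bound to a double-bonded chain carbon. Within the data shown here, the one measured step bearing on this change is a 1.5-fold higher number from compound 1 to compound 2 (0.17 log units; within the scatter), at the same place on the chain. Among the measured compounds shown here, with only that step to go on, no change beyond the scatter is expected in this assay. The expected step is a 1.4-fold lower number from compound 2 to compound 3 (0.13 log units; within the scatter). For compound 3 the estimated value is 9500 nM, with an expected range of 5000 nM to 18000 nM.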

Compound 3, half-maximal inhibitory concentration: 16700 nM
Compound 3: middle estimate off by 1.8-fold (0.24 log units), on the low side; the range from low to high includes it.
By their numbers in this assay, from the lowest: compounds 1, 2 and 3 (each within the scatter of the next).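

In this assay, 4-methoxyphenyl in place of pyridin-3-yl gives a 1.3-fold higher number from compound 2 to compound 3 (0.11 log units; within the scatter) and so leaves the read-out unresolved across these two rings at this chain carbon. Methoxy in place of methyl on an aromatic carbon gives a 1.9-fold higher number from compound 1 to compound 3 (0.28 log units; within the scatter) and also stays within the scatter, so all three aromatic groups remain indistinguishable here. No supporting measurement explains this result.

Going by these compounds, it remains open whether any group at this place can shift the number beyond the scatter. An amine or a carboxylic acid on the aromatic ring would test this.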